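The source may hold more compounds than are shown below. What is called first, only, known or untested is meant among the compounds shown, and "the series" means these compounds.

Of the compounds shown here, three built on one shared core have been tested for how strongly they hold back the growth of prostate cancer cells. Compound 1 `COc1cc(/C=C/C(=O)Nc2cc3c(Nc4ccc(F)c(Cl)c4)ncnc3cc2O[C@H]2CCOC2)cc(OC)c1O` gives 26500 nM in a functional assay on PC-3 cells (Homo sapiens) for cytotoxicity, read by MTT assay, with a stated time of 72 h; a higher number here means a weaker inhibitor, a lower number a stronger inhibitor. Compound 2 `COc1cc(/C=C/C(=O)Nc2cc3c(Nc4ccc(F)c(Cl)c4)ncnc3cc2O[C@H]2CCOC2)cc(OC)c1OC` gives 20500 nM. Compound 3 `O=C(/C=C/c1ccc(Br)cc1)Nc1cc2c(Nc3ccc(F)c(Cl)c3)ncnc2cc1O[C@H]1CCOC1` gives 28200 nM. Compound 3 thus shows the highest of the three numbers, yet every gap to it is small: a 1.1-fold higher number from compound 1 to compound 3 (0.03 log units; within the scatter), and a 1.4-fold higher number from compound 2 to compound 3 (0.14 log units; within the scatter). Within the data shown here, the one change on the other side of the molecule, a 1.3-fold lower number from compound 1 to compound 2 (0.11 log units; within the scatter), is also small. So far, then, swapping the aryl group at the end of the double-bonded chain between three quite different options has moved nothing beyond the usual scatter of this assay.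

Compound 4 `O=C(/C=C/c1cc(Br)c(O)c(Br)c1)Nc1cc2c(Nc3ccc(F)c(Cl)c3)ncnc2cc1O[C@H]1CCOC1` is the next member of the series. It differs from compound 3 in one place: 3,5-dibromo-4-hydroxyphenyl in place of 4-bromophenyl on a double-bonded chain carbon bound to a double-bonded chain carbon. The nearest measured steps, those from compound 1 and compound 2 to compound 3, are both within the scatter, and no other comparison in this set shows a change at this position that matters. Compound 4 is therefore expected to give a number close to compound 3, with the expected step being a 1.0-fold lower number from compound 3 to compound 4 (0.02 log units; within the scatter). The estimate for compound 4 is 27000 nM, with a range from 13000 nM to 56000 nM.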

Compound 4, half-maximal inhibitory concentration: 25500 nM
Estimate against measurement, compound 4: 1.1-fold (0.02 log units) above; the measured number falls inside the stated range.
By their numbers in this assay, from the lowest: compounds 2, 4, 1 and 3 (each within the scatter of the next).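

Set in place of 4-bromophenyl, the 3,5-dibromo-4-hydroxyphenyl group is a larger aryl group that carries a hydrogen-bond donor and a hydrogen-bond acceptor, yet a 1.1-fold lower number from compound 3 to compound 4 (0.04 log units; within the scatter) is all that this assay shows for this change. Set against the two methoxy-bearing groups, the same group gives a 1.2-fold higher number from compound 2 to compound 4 (0.09 log units; within the scatter) and a 1.0-fold lower number from compound 1 to compound 4 (0.02 log units; within the scatter) as its steps, and the second of these shows that bromine atoms can stand in place of the two methoxy groups of 4-hydroxy-3,5-dimethoxyphenyl with no change beyond the scatter. All four aryl groups now tested on this double-bonded chain carbon therefore stay within the scatter of one another, a flat result that widens the earlier picture to a more heavily substituted ring, and no further data are available to explain it.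

Every compound shown keeps a six-membered aromatic ring of carbon at this place, so it remains open whether the numbers would move with an amine or a carboxylic acid on that ring, or with a saturated ring in its place. The four compounds also share everything else in the molecule, so these steps say nothing about changes made elsewhere on the shared core.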